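The compounds below may be only part of what the source reports. "The series", "measured", "known", "first", "only" and "open" are said of these compounds alone.

Working notes on the series in a functional assay on the whole organism with Rattus norvegicus as the target; on this read-out lower numbers stand for an effect already at smaller amounts and higher numbers for an effect only at larger amounts of compound.

Compound 1, `Nc1nc2ccc(C3CCCCC3)cc2s1`, is reported only as a limit of the assay: in this assay compound 1 gives > 10 mg/kg, the threshold described as the limit of > 10 mg/kg in this assay, at which 1 of the 3 values shown sits. Compound 2, `CC(C)(C)c1ccc2nc(N)sc2c1`, gives 4 mg/kg in this assay. Compound 3, `CCCCn1c(=N)sc2cc(OC(F)(F)F)ccc21`, gives 10 mg/kg in this assay, the highest of the two numbers on record; its nearest neighbour is compound 2, which sits at a lower number, a gap beyond the scatter.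

Compound 4, `N=c1sc2cc(OC(F)(F)F)ccc2n1CCS`, differs from compound 3 in one place: sulfanyl in place of ethyl on a saturated chain carbon, two bonds along the chain from an aromatic nitrogen. Cut one bond further out, the same change reads butyl to 2-sulfanylethyl. Among the compounds with values here, no measured step resembles this change, so nothing on record fixes its size or direction. With a single fixed point, the step from compound 3 to compound 4 is expected to be no change at the digits printed from compound 3 to compound 4 (within the scatter), essentially no movement beyond the scatter.

For compound 4 the expected value in this assay is 10 mg/kg, within a range of 3 mg/kg to 30 mg/kg.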

Compound 4, dose for half-maximal effect: 2 mg/kg
Beside the measured number, compound 4's estimate is 5.0-fold (0.70 log units) above it; the whole stated range lies above it.
By their numbers in this assay, from the lowest: compounds 4 and 2 (each within the scatter of the next); then compound 3.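

In this assay, within the data shown here, sulfanyl in place of ethyl on a saturated chain carbon, two bonds along the chain from an aromatic nitrogen, gives a 5.0-fold lower number from compound 3 to compound 4 (0.70 log units; beyond the scatter) and so provides the first reading at this position. The outcome shows that the end of this chain is not indifferent to the group it carries, and that butyl to 2-sulfanylethyl moves the number beyond the scatter. Nothing on record accounts for the direction or size of this step.

From the compounds shown here alone, whether the step belongs to the sulfur atom itself or to the loss of the ethyl remains open, as a hydroxyl, an amine or a methylthio group at the same place would be needed to separate the two. Going by these compounds, how a longer chain ending in sulfanyl would read in this assay also remains open.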